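A few compounds are considered here, and "the series" means these few. Any claim that something is new, unique, unknown or untested is made for them only; others in the source may bear on it.

Measured compounds:
compound 1 `O=C1c2c[n+]([O-])c3ccccc3c2C(=O)c2c1c1ccccc1n2Cc1cn([C@@H]2C[C@H](O)[C@@H](CO)O2)nn1`, 130 nM
compound 2 `O=C1c2c[n+]([O-])c3ccccc3c2C(=O)c2c1c1ccccc1n2CCN1CCCC1`, 630 nM
compound 3 `O=C1c2c[n+]([O-])c3ccccc3c2C(=O)c2c1c1ccccc1n2CCN1CCCCC1`, 1050 nM

All three share one core and differ only in the group on the indole-type nitrogen of that core. In a functional assay on MDA-MB-231 cells (Homo sapiens) for cytotoxicity, read by MTT assay, with a stated time of 72 h (on this read-out lower numbers stand for stronger inhibition and higher numbers for weaker inhibition), compound 1 gives the lowest of the three numbers; the step of a 1.7-fold higher number from compound 2 to compound 3 (0.22 log units; within the scatter) lies within the scatter, and both compound 2 and compound 3 lie well above compound 1.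

Compound 4 `O=C1c2c[n+]([O-])c3ccccc3c2C(=O)c2c1c1ccccc1n2Cc1cn(C[C@@H](O)CO)nn1` keeps the triazolylmethyl arm of compound 1 and differs only there: 2,3-dihydroxypropyl in place of 4-hydroxy-5-(hydroxymethyl)oxolan-2-yl on an aromatic nitrogen. For the measured compounds named here, none of the measured steps concerns this position; the only measured step, between compound 2 and compound 3, alters a different arm and was within the scatter. Going by the values given here, there is therefore no direct precedent for the step in this assay, and a small loss is expected rather than a gain. Compound 4 is estimated at 260 nM, range 100 nM to 700 nM, an expected step of a 2.0-fold higher number from compound 1 to compound 4 (0.30 log units; within the scatter).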

Compound 4, half-maximal inhibitory concentration: 670 nM
Beside the measured number, compound 4's estimate is 2.6-fold (0.41 log units) below it, and the stated range covers the measured number.
By their numbers in this assay, from the lowest: compound 1; then compounds 2, 4 and 3 (each within the scatter of the next).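

In this assay, the group on this aromatic nitrogen clearly affects the result: 2,3-dihydroxypropyl in place of 4-hydroxy-5-(hydroxymethyl)oxolan-2-yl gives (a 5.2-fold higher number from compound 1 to compound 4 (0.71 log units; beyond the scatter)). With 2,3-dihydroxypropyl, the triazole-bearing arm does not stand apart from the arms ending in piperidin-1-yl (a 1.6-fold lower number from compound 3 to compound 4 (0.20 log units; within the scatter)) or pyrrolidin-1-yl (a 1.1-fold higher number from compound 2 to compound 4 (0.03 log units; within the scatter)), so the arm alone does not carry the low number of compound 1. Nothing available explains this step.

Still open, going by these compounds, is whether the ring or its defined stereocentres matter. An oxolane ring lacking the hydroxymethyl, or a carboxylic acid on this nitrogen, would test the position further.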